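Swapping Amino for 2-Methylphenyl on the Ring Nitrogen

A few compounds are considered here, and "the series" means these few. Any claim that something is new, unique, unknown or untested is made for them only; others in the source may bear on it.

Of the compounds shown here, three sharing one core have been tested in a functional assay on the whole organism (strain Sprague-Dawley) for inhibition, with Rattus norvegicus as the target, read by paw edema, with a stated time of 1 h, at a dose of 70 mg/kg by the subcutaneous route; a higher number here means more inhibition at the dose given (going by the name of the read-out), a lower number less inhibition. Compound 1 `Cc1c(-n2c(-c3ccccc3)c(-c3ccccc3)c3c(Nc4ccccc4)ncnc32)n(C)n(-c2ccccc2)c1=O` gives 1.99%. Compound 2 `Cc1c(-n2c(-c3ccccc3)c(-c3ccccc3)c3c(N/N=C/c4ccccc4)ncnc32)n(C)n(-c2ccccc2)c1=O` gives 47.8%. Compound 3 `Cc1c(-n2c(-c3ccccc3)c(-c3ccccc3)c3c(NN)ncnc32)n(C)n(-c2ccccc2)c1=O` gives 43.7%. On these numbers compound 3 stands second highest of the three; its nearest neighbour is compound 2, a gap within the scatter, and the furthest is compound 1, a gap well beyond it. The two steps that raised inhibition both replaced the phenyl on the ring nitrogen: a number 45.8 percentage points higher from compound 1 to compound 2 (beyond the scatter) and a number 41.7 percentage points higher from compound 1 to compound 3 (beyond the scatter). Between the two replacements themselves, a number 4.1 percentage points lower from compound 2 to compound 3 (within the scatter).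

Compound 4 `Cc1ccccc1Nc1ncnc2c1c(-c1ccccc1)c(-c1ccccc1)n2-c1c(C)c(=O)n(-c2ccccc2)n1C` has not yet been measured. 2-methylphenyl in place of amino on a nitrogen on an aromatic ring This change brings a six-membered aromatic ring of carbon only back onto that nitrogen, so the step that bears on it most directly is a number 41.7 percentage points higher from compound 1 to compound 3 (beyond the scatter) read in reverse: compound 1 carries phenyl on the same nitrogen and is the lowest of the three. A fall beyond the scatter is therefore expected, a number 37.7 percentage points lower from compound 3 to compound 4 (beyond the scatter). Compound 4 is estimated at 6%, with a range from 0% to 25%. Only compound 1 offers a comparison for an aromatic ring on this nitrogen, so the estimate rests on a single pair.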

Compound 4, a percentage reported as inhibition, in the whole organism at one dose (the size of the read-out at that dose, not a potency): 1.95%
For compound 4 the middle estimate is 4.1 percentage points above the measured one; the measured number falls inside the stated range.
By their numbers in this assay, from the lowest: compounds 4 and 1 (each within the scatter of the next); then compounds 3 and 2 (each within the scatter of the next).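

In this assay, 2-methylphenyl in place of amino on this nitrogen removes almost all of the inhibition, a number 41.8 percentage points lower from compound 3 to compound 4 (beyond the scatter), and the loss is as large against the longer group of compound 2, a number 45.9 percentage points lower from compound 2 to compound 4 (beyond the scatter). Adding a methyl to the phenyl ring makes no readable difference, a number 0 percentage points lower from compound 1 to compound 4 (within the scatter), so among these four compounds the low reading now appears with two aromatic rings joined through this nitrogen, while compound 2 and compound 3, which both carry a further nitrogen there, keep their inhibition. Nothing available explains why the reading falls with these rings.

The compounds shown leave open whether that further nitrogen matters or whether the aromatic ring itself is what lowers the reading, which a simple methyl, a longer alkyl chain or a benzyl group on this nitrogen could help to separate. From the compounds shown here alone, it also remains open whether a ring carrying a hydroxyl or a carboxylic acid in place of the methyl would stay as low as compound 4 and compound 1.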